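The compounds below may be only part of what the source reports. "The series", "measured", "known", "first", "only" and "open" are said of these compounds alone.

Measured in an in vitro assay on HEK293 cells with Alpha-1D adrenergic receptor (Homo sapiens) as the target; a lower number here means a stronger inhibitor, a higher number a weaker inhibitor:

compound 1, `N#Cc1ccccc1C1CCN(CCCNC(=O)C2=C(C(F)(F)F)NC(=O)N[C@@H]2c2ccc(F)c(F)c2)CC1`: 220 nM
compound 2, `O=C1NC(C(F)(F)F)=C(C(=O)NCCCN2CCC(c3ccc(F)cc3)CC2)[C@@H](c2ccc(F)c(F)c2)N1`: 1200 nM
compound 3, `COCC1=C(C(=O)NCCCN2CCC(c3ccc(F)cc3)CC2)[C@@H](c2ccc(F)c(F)c2)NC(=O)N1`: 260 nM

Compound 3 stands second highest of the three numbers in this assay. Its nearest neighbour is compound 1, whose number is within the usual scatter of that of compound 3, so the two cannot be ordered; the furthest is compound 2, which gives a number beyond the scatter from that of compound 3, as the step of a 4.6-fold lower number from compound 2 to compound 3 (0.66 log units; beyond the scatter) shows.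

The step to compound 4, `COCC1=C(C(=O)NCCCN2CCC(c3ccc(F)cc3C#N)CC2)[C@@H](c2ccc(F)c(F)c2)NC(=O)N1`, is cyano in place of hydrogen on an aromatic carbon. Among the measured compounds shown here, one measured step bears on it: the change from a cyano-bearing aryl to a plain fluorophenyl on the saturated ring carbon, a 5.5-fold higher number from compound 1 to compound 2 (0.74 log units; beyond the scatter), a modest rise in the number. Compound 4 runs that change the other way, though it keeps the fluoro group beside the added cyano, so the two cases are not identical. The expectation for compound 4 is therefore a modest fall in the number, a 3.3-fold lower number from compound 3 to compound 4 (0.51 log units; beyond the scatter), on the strength of the step from compound 1 to compound 2 alone.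

Compound 4 is thus estimated at 80 nM in this assay, with a range from 30 nM to 250 nM.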

Compound 4, inhibition constant: 260 nM
For compound 4 the middle estimate is 3.3-fold (0.51 log units) below the measured one; measured number above the stated range.
By their numbers in this assay, from the lowest: compounds 1, 3 and 4 (each within the scatter of the next); then compound 2.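

In this assay, cyano in place of hydrogen on an aromatic carbon, which turns 4-fluorophenyl into 2-cyano-4-fluorophenyl, gives no change at the digits printed from compound 3 to compound 4 (within the scatter), so the two compounds cannot be ordered. The earlier step, a 5.5-fold higher number from compound 1 to compound 2 (0.74 log units; beyond the scatter), exchanged 2-cyanophenyl for 4-fluorophenyl with trifluoromethyl on the double-bonded ring carbon, and so removed the cyano and brought in the fluoro group at once; the new pair changes the cyano alone, with the fluoro group kept and methoxymethyl on that ring carbon, and shows that in this setting a cyano at this place does not by itself produce a step beyond the scatter. Nothing measured here explains why the cyano counts for so little in this pair.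

The compounds shown leave open whether the earlier step depended on the trifluoromethyl group, on the loss of the fluoro group, or on both, since no pair separates these. They also leave open how a carboxamide or a chloro group at the same aromatic carbon would read in this assay, and whether a cyano there would matter with trifluoromethyl on the double-bonded ring carbon.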